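Adding two methoxy groups to the aryl hydrazone arm

A few compounds are considered here, and "the series" means these few. Any claim that something is new, unique, unknown or untested is made for them only; others in the source may bear on it.

Compound 1: `Cc1nc(N(C)C(=O)NC(=O)c2c(F)cccc2F)sc1C(=O)N/N=C/c1cccc(C(F)(F)F)c1` — 31.6 ug/mL
Compound 2: `Cc1nc(N(C)C(=O)NC(=O)c2c(F)cccc2F)sc1C(=O)N/N=C/c1ccccc1F` — > 100 ug/mL
Compound 3: `COc1ccc(/C=N/NC(=O)c2sc(N(C)C(=O)NC(=O)c3c(F)cccc3F)nc2C)cc1` — 22.7 ug/mL

All three compounds share one core and differ only in the aryl group on the carbon with a double bond to nitrogen. In a functional assay on HepG2 cells (Homo sapiens) for inhibition, read by MTT assay, with a stated time of 72 h (a lower number here means a stronger inhibitor, a higher number a weaker inhibitor), compound 3 gives 22.7 ug/mL and compound 1 gives 31.6 ug/mL. For compound 2 the result is only a limit, > 100 ug/mL, so no number is known for it (the limit of > 100 ug/mL in this assay, at which 1 of the 3 values shown sits). Compound 3 thus holds the lowest of the two numbers, but its gap to compound 1 is small: a 1.4-fold lower number from compound 1 to compound 3 (0.14 log units; within the scatter). The step from the fluorinated aryl group is larger, an at least 4.4-fold lower number from compound 2 to compound 3 (0.64 log units; beyond the scatter), and an at least 3.1-fold higher number from compound 1 to compound 2 (0.50 log units; beyond the scatter).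

Compound 4 is `COc1cc(/C=N/NC(=O)c2sc(N(C)C(=O)NC(=O)c3c(F)cccc3F)nc2C)cc(OC)c1OC`. It differs from compound 3 in one place: 3,4,5-trimethoxyphenyl in place of 4-methoxyphenyl on a carbon with a double bond to nitrogen. For the measured compounds named here, no measured step changes the number of methoxy groups, so the nearest guide is that swapping aryl groups moved the result by at most a modest amount, and only once beyond the scatter. A change of about that size or smaller is expected in this assay , in either direction. Compound 4 is estimated at 20 ug/mL, with a range from 7 ug/mL to 60 ug/mL, which means an expected step of a 1.1-fold lower number from compound 3 to compound 4 (0.05 log units; within the scatter).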

Compound 4, half-maximal inhibitory concentration: > 100 ug/mL
Compound 4: a limit, no number; the forecaster's own chance of this, stated with the estimate: 12%; middle value at least 5.0-fold (0.69 log units) away from the limit.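

The result for compound 4 in this assay is a limit, not a number. Going from the 4-methoxyphenyl group to the 3,4,5-trimethoxyphenyl group is the first change here in the number of methoxy groups, and it gives an at least 4.4-fold higher number from compound 3 to compound 4 (0.64 log units; beyond the scatter), so on this carbon a methoxy-bearing aryl group is not enough on its own to keep a measurable number; the comparison with the 3-(trifluoromethyl)phenyl group points the same way, with an at least 3.1-fold higher number from compound 1 to compound 4 (0.50 log units; beyond the scatter). The step between compound 2 and compound 4 cannot be read, since both results stop at the same limit: the limit of > 100 ug/mL in this assay, at which 2 of the 4 values shown sit.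

The compounds shown do not separate the number of methoxy groups from their placement on the ring. From the compounds shown here alone, how a dimethoxyphenyl group, or an aryl group carrying an amine or a carboxylic acid, would behave on this carbon also stays open.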